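Hydroxy-cyclic-amine sulfonamides on the shared core: ring contraction

This account rests on a few compounds, and the source may have more. Where it says the series, first, only, none or still open, it means among the compounds named here.

Compound 1 `O=S(=O)(c1cccc(-c2ccc3nccc(-c4ccncc4)c3n2)c1)N1CCC(O)CC1` carries a sulfonyl group on the aryl ring that joins the shared core. In an ADME assay on microsomes from liver (Mus musculus) for metabolic stability, read by LC-MS, using NADPH, with a stated time of 30 min, tested at 0.1 uM (a lower number here means that less of the compound is left, a higher number that more of the compound is left), compound 1 gives 7%. Within this small set that reading is the second highest of three numbers. Compound 3 `NS(=O)(=O)c1cncc(-c2ccc3nccc(-c4cn[nH]c4)c3n2)c1` gives 2% in this assay, a number within the scatter of compound 1. Compound 2 `O=S(=O)(NCCO)c1cccc(Nc2ccc3nccc(-c4ccncc4)c3n2)c1`, which links its aryl ring to the core through an amine, gives 38% in this assay, beyond the scatter of both compound 1 and compound 3.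

Compound 4 `O=S(=O)(c1cccc(-c2ccc3nccc(-c4ccncc4)c3n2)c1)N1CC[C@H](O)C1` is not yet measured. It differs from compound 1 in one place: 3-hydroxypyrrolidin-1-yl in place of 4-hydroxypiperidin-1-yl on a sulfonyl sulfur

For the measured compounds named here, no pair of measured compounds shows a step of this kind, so the size of the change is not anchored by the data. Both ring amides of this kind so far sit low in this assay, and compound 1 at 7% gives the only direct reference. The step of a number 3 percentage points higher from compound 1 to compound 4 (within the scatter) is expected to be small, with no direction beyond the scatter. For compound 4 the estimate in this assay is 10%, with a range from 2% to 25%.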

Compound 4, percent of the compound remaining: 12%
The estimate for compound 4 lay 2 percentage points below the measured number; low and high end bracket the measured number.
By their numbers in this assay, from the lowest: compounds 3, 1 and 4 (each within the scatter of the next); then compound 2.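

Notes on the ring contraction: this pair gives the first anchored step for the amine on the sulfonyl sulfur. In this assay, 3-hydroxypyrrolidin-1-yl in place of 4-hydroxypiperidin-1-yl gives a number 5 percentage points higher from compound 1 to compound 4 (within the scatter), so within this pair the change from a six-membered to a five-membered hydroxy ring does not move the reading beyond the scatter. Nothing on hand bears on a reason for this reading.

Still open, going by these compounds, is whether the opposite stereocentre of 3-hydroxypyrrolidin-1-yl, or a ring amine with another hetero atom or without the hydroxyl, such as morpholin-4-yl or piperidin-1-yl, would read alike at this sulfonyl sulfur. Also open, on these data alone, is whether a 2-hydroxyethylamino group on the sulfonyl sulfur, with the aryl ring joined directly to the shared core, would read nearer to compound 1 or to compound 2.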